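Chain Length and Metabolic Stability in Carbamate Amides

A few compounds are considered here, and "the series" means these few. Any claim that something is new, unique, unknown or untested is made for them only; others in the source may bear on it.

Three compounds built on a carbamate-amide core were measured in an ADME assay for metabolic stability, read by HPLC, at pH 7.4; a higher number here means that the compound lasts longer, a lower number that the compound disappears faster. Compound 1 `CCCCCNC(=O)Oc1ccc(Cl)cc1C(=O)Nc1cccc(Cl)c1` gives 43 h. Compound 2 `CCCCCCNC(=O)Oc1ccc(Cl)cc1C(=O)Nc1cccc(Cl)c1` gives 43 h. The step of no change at the digits printed from compound 1 to compound 2 (within the scatter) came from methyl in place of hydrogen on a saturated chain carbon, five bonds along the chain from an amide-type nitrogen. Compound 3 `CCNC(=O)Oc1ccc(Cl)cc1C(=O)Nc1ccc(Cl)cc1` differs from compound 1 in more than one place, so the difference between the two cores is not broken down here; in this assay compound 3 gives 43 h, level with compounds 1 and 2 within the scatter.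

Compound 4 `CCCNC(=O)Oc1ccc(Cl)cc1C(=O)Nc1ccc(Cl)cc1` is to be measured in this assay. It differs from compound 3 by methyl in place of hydrogen on a saturated chain carbon, two bonds along the chain from an amide-type nitrogen. This is the same kind of change as that between compound 1 and compound 2, but not the same: there the methyl entered five bonds along the chain from an amide-type nitrogen, here it enters two bonds along the chain from an amide-type nitrogen. The step of no change at the digits printed from compound 3 to compound 4 (within the scatter) is expected to be small, because the step of no change at the digits printed from compound 1 to compound 2 (within the scatter) stayed within the scatter and because compound 3 gives 43 h. Compound 4 is therefore estimated at 43 h, between 22 h and 86 h.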

Compound 4, half-life: 43 h
For compound 4 middle estimate and measured number coincide at the digits printed; the measured number falls inside the stated range.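

In this assay, methyl in place of hydrogen on a saturated chain carbon, two bonds along the chain from an amide-type nitrogen, gave no change at the digits printed from compound 3 to compound 4 (within the scatter). Set beside the earlier step on the other core, this result shows that the methyl change carried over with the same outcome: the same change on two cores in this assay, no change at the digits printed (within the scatter) from compound 1 to compound 2 and no change at the digits printed (within the scatter) from compound 3 to compound 4, 1.0-fold (0.00 log units) apart, within the scatter of two such steps It does not show that the outcome holds on every core in this series, since only two pairs are available and the methyl enters at a different place in each, five bonds along the chain in one and two bonds along it in the other.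

The compounds shown leave open whether a longer chain, a branched chain such as isopropyl, or a chain ending in an amine or a carboxylic acid would give the same outcome in this assay. They also leave open whether the methyl step would carry over to a core in which a urea takes the place of the carbamate.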